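Hydroxy in place of chloro on compound 1

The source may hold more compounds than are shown below. What is called first, only, known or untested is meant among the compounds shown, and "the series" means these compounds.

Compound 1 `O=c1c(Cc2coc3cccc(OCC4CCCCC4)c3c2=O)coc2cc(Cl)ccc12` gives > 10000 nM as a limit
Compound 2 `CC(C)COc1cccc2occ(Cc3coc4ccccc4c3=O)c(=O)c12` gives > 10000 nM as a limit
Compound 3 `CC(C)CCOc1cccc2occ(Cc3coc4ccccc4c3=O)c(=O)c12` gives > 10000 nM as a limit

In a functional assay on NCI-H23 cells (Homo sapiens) for antiproliferative activity, read by XTT assay (on this read-out lower numbers stand for stronger inhibition and higher numbers for weaker inhibition), compound 1 stands at > 10000 nM and has only a limit, not a number. The series offers the limit of > 10000 nM in this assay, at which 3 of the 3 values shown sit, and nothing firmer. Compound 4 `O=c1c(Cc2coc3cccc(OCC4CCCCC4)c3c2=O)coc2cc(O)ccc12` differs by hydroxy in place of chloro on an aromatic carbon with hydroxy in place of chloro on an aromatic carbon. For the measured compounds named here, the one measured step that the two limits leave unreadable from compound 2 to compound 3 concerns another group and gives no size to carry over. The expectation therefore rests on compound 1 with > 10000 nM as its limit. The expected outcome is a number no higher from compound 1 to compound 4 (the limit leaves the size open) with no direction favoured by the data. Compound 4 is estimated at 10000 nM with an expected range from 3000 nM to 30000 nM in this assay here.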

Compound 4, half-maximal inhibitory concentration: 2150 nM
Compound 4: the middle estimate sits 4.7-fold (0.67 log units) above what was measured, and the stated range ends above it.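

In this assay, hydroxy in place of chloro on an aromatic carbon gives an at least 4.6-fold lower number from compound 1 to compound 4 (0.66 log units; beyond the scatter), so a change at this position can move the read-out. The step between the two earlier ether compounds, compound 2 and compound 3, cannot be read. Compound 4 is the only compound shown with a number rather than a limit: the limit of > 10000 nM in this assay, at which 3 of the 4 values shown sit.

On these data alone, the full size of the step stays open, as compound 1 has only a limit. Also open, as far as these compounds go, is how an amine or a methoxy group would behave at this position.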